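Allyloxy for thiophenyl in a weakly cytotoxic pyrrolidine series

The compounds below may be only part of what the source reports. "The series", "measured", "known", "first", "only" and "open" are said of these compounds alone.

The measured compounds:
Compound 1 `OC[C@H](NC[C@H]1NC[C@H](O)[C@@H]1O)c1ccc(-c2ccccc2)cc1` in a functional assay on BT-474 cells (Homo sapiens) for cytotoxicity, read by colorimetric assay, with a stated time of 72 h (a higher number here means a weaker inhibitor, a lower number a stronger inhibitor), reaches only the assay limit > 200000 nM.
Compound 2 `OC[C@H](NC[C@H]1NC[C@H](O)[C@@H]1O)c1ccc(-c2ccc(C(F)(F)F)cc2)cc1` in this assay gives 93000 nM.
Compound 3 `OC[C@H](NC[C@H]1NC[C@H](O)[C@@H]1O)c1ccc(-c2ccsc2)cc1` in this assay is reported as "not active" (no number reported).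

Compound 3 thus has no number at all; of the remaining values, one is a limit of > 200000 nM in this assay, at which 1 of the 3 values shown sits, and only compound 2 supplies a figure. Within the data shown here, the only measured step, an at least 2.1-fold lower number from compound 1 to compound 2 (0.33 log units; beyond the scatter), is at least modest. Compound 4 `C=CCOc1ccc([C@H](CO)NC[C@H]2NC[C@H](O)[C@@H]2O)cc1` differs from compound 3 by allyloxy in place of thiophen-3-yl on an aromatic carbon. Among the measured compounds shown here, no measured step touches this change, so no direction beyond the scatter can be claimed. Compound 4 is estimated at 200000 nM, expected to fall between 50000 nM and 600000 nM, with a real chance of only a limit.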

Compound 4, half-maximal inhibitory concentration: > 200000 nM
Compound 4 gave a limit, no number (the forecaster's own chance of this, stated with the estimate: 60%); the middle value sits exactly at the limit.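

In this assay compound 4 gives > 200000 nM, a limit and not a number. Among these compounds, compound 1 also stands at a limit, so no step to compound 4 can be read. The compounds shown leave open whether allyloxy in place of phenyl or thiophen-3-yl changes the read-out at all.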